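Chloro to methoxy on an aryl ether: lipophilicity

A few compounds are considered here, and "the series" means these few. Any claim that something is new, unique, unknown or untested is made for them only; others in the source may bear on it.

Compound 1 `Cc1cc(COc2ccccc2Cl)nc(-c2ccccn2)n1` and compound 2 `Cc1cc(COc2ccc(Cl)cc2)nc(-c2ccccn2)n1` share the same atoms joined differently; their difference is 4-chlorophenyl in place of 2-chlorophenyl on an oxygen on a saturated carbon. In a physicochemical assay for lipophilicity, at pH 7.4 (on this read-out higher numbers stand for higher lipophilicity and lower numbers for lower lipophilicity), compound 1 gives 3.4 and compound 2 gives 3.7, a step of a number 0.30 log units higher from compound 1 to compound 2 (within the scatter). Compound 3 `COc1ccccc1OCc1cc(C)nc(-c2ccccn2)n1` differs from compound 1 by methoxy in place of chloro on an aromatic carbon, and in this assay compound 3 gives 2.5, a step of a number 0.90 log units lower from compound 1 to compound 3 (beyond the scatter).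

Compound 4 `COc1ccc(OCc2cc(C)nc(-c3ccccn3)n2)cc1` is not yet measured. It differs from compound 2 by methoxy in place of chloro on an aromatic carbon. This is the same kind of change as from compound 1 to compound 3, though the place differs: ortho to a large group there, para to a large group here. Because compound 1 to compound 3 gave a number 0.90 log units lower from compound 1 to compound 3 (beyond the scatter), a step of about a number 0.90 log units lower from compound 2 to compound 4 (beyond the scatter) is expected for compound 4. Compound 4 is estimated at 2.8, between 2.4 and 3.2.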

Compound 4, distribution coefficient: 2.8
For compound 4 middle estimate and measured number coincide at the digits printed; low and high end bracket the measured number.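

In this assay, the change from chloro to methoxy gives a number 0.90 log units lower from compound 2 to compound 4 (beyond the scatter), which is the same size as a number 0.90 log units lower from compound 1 to compound 3 (beyond the scatter). For the compounds shown here, the change therefore carried over between these two pairs, including to the aromatic carbon para to a large group in compound 4, but that is only two pairs on one shared core and does not show that the step would hold on a different core. Nothing in the data gives a reason for the size of the step.

As far as these compounds go, it remains open whether the step would be repeated with the methoxy replaced by a longer chain such as butoxy. An amine or a carboxylic acid in place of chloro also remains an open case.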